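A few compounds are considered here, and "the series" means these few. Any claim that something is new, unique, unknown or untested is made for them only; others in the source may bear on it.

Among the compounds with values here, compound 2 `CCCCCCCCc1ccc(OCC(=O)Cn2nnc(-c3ccncc3)n2)cc1` gives 24 nM in an assay on microsomes from brain for inhibition of Fatty-acid amide hydrolase 1 (Rattus norvegicus), read by fluorescence and HPLC, with a stated time of 60 min (a lower number here means a stronger inhibitor, a higher number a weaker inhibitor), the lower of the two numbers measured so far, though within the scatter of compound 1 `CCCCCCCCc1ccc(OCC(=O)Cn2nnc(-c3ccc(Cl)cc3)n2)cc1`, which gives 35 nM; that pair shows a 1.5-fold lower number from compound 1 to compound 2 (0.16 log units; within the scatter). Compound 3 `CCCCCCCCc1ccc(OCC(=O)Cn2nnc(C(=O)O)n2)cc1` differs from compound 2 by carboxy in place of pyridin-4-yl on an aromatic carbon. Within the data shown here, the only measured step exchanges one six-membered aromatic ring for another and stays within the scatter, so it offers no guide to removing the ring altogether. Compound 3 is therefore expected to show a higher number, by a 42-fold higher number from compound 2 to compound 3 (1.62 log units; beyond the scatter). The estimate for compound 3 is 1000 nM, with a range from 150 nM to 10000 nM.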

Compound 3, half-maximal inhibitory concentration: 41 nM
Compound 3: middle estimate off by 24-fold (1.39 log units), on the high side; the whole stated range lies above it.
By their numbers in this assay, from the lowest: compounds 2, 1 and 3 (each within the scatter of the next).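

Replacing the ring with carboxy gives a 1.7-fold higher number from compound 2 to compound 3 (0.23 log units; within the scatter) and a 1.2-fold higher number from compound 1 to compound 3 (0.07 log units; within the scatter) and neither step goes beyond the scatter. So, among these compounds, a six-membered aromatic ring at this position is not needed to keep the number in this range, and a much smaller group with no ring serves equally well. Nothing available explains why the numbers stay so close. Still open, as far as these compounds go, is how a plain hydrogen, a methyl ester or an amine would behave at this position. The compounds shown also cannot tell whether any group here would move the number beyond the scatter.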